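Series notes: from compound 3 to compound 4 in liver microsomes

The source may report more compounds than this note shows. Statements on the series, on what has been measured and on what is new or still open speak of the compounds shown alone.

Measured so far:
compound 1 `Fc1cc(Cl)ccc1-c1ccc(Cn2nnc3ccccc32)cn1` — 0.8 mL/min/g
compound 2 `Fc1ccccc1-c1ccc(Cn2nnc3ccccc32)cn1` — "not determined" (no result reported)
compound 3 `Fc1cc(Cl)ccc1-c1ccc(Cn2nnc3c(F)cccc32)cn1` — 0.6 mL/min/g

In an ADME assay on microsomes from liver (Rattus norvegicus, strain Wistar) for metabolic stability, tested at 2.5 uM (a lower number here means slower removal, a higher number faster removal of the compound), compound 1 gives 0.8 mL/min/g and compound 3 gives 0.6 mL/min/g. In this assay compound 2 gives "not determined" (no result reported), so no number is on hand for it. Within the data shown here, compound 3 thus stands at the lower of the two numbers, yet the only step, a 1.3-fold lower number from compound 1 to compound 3 (0.12 log units; within the scatter), is within the scatter, so compound 1 and compound 3 are not separated.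

Compound 4 `N#Cc1cccc2c1nnn2Cc1ccc(-c2ccc(Cl)cc2F)nc1` differs from compound 3 by cyano in place of fluoro on an aromatic carbon. Among the measured compounds shown here, no measured step involves a cyano group; the one step on hand concerns fluoro for hydrogen and was within the scatter. A step of a 1.2-fold higher number from compound 3 to compound 4 (0.07 log units; within the scatter) is therefore expected, that is nothing beyond the scatter. Compound 4 is estimated at 0.7 mL/min/g, within 0.3 mL/min/g to 1.6 mL/min/g.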

Compound 4, intrinsic clearance in a liver preparation (reported as CLH), per the amount of preparation that the assay uses: 0.1 mL/min/g
For compound 4 the middle estimate is 7.0-fold (0.85 log units) above the measured one, outside the stated range (below it).
By their numbers in this assay, from the lowest: compound 4; then compounds 3 and 1 (each within the scatter of the next).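

In this assay the group on this aromatic carbon now matters: cyano in place of fluoro gives a 6.0-fold lower number from compound 3 to compound 4 (0.78 log units; beyond the scatter) and cyano in place of hydrogen gives an 8.0-fold lower number from compound 1 to compound 4 (0.90 log units; beyond the scatter) on the same core. Fluoro in place of hydrogen stayed within the scatter at this carbon, so among these compounds the position responds to cyano but not to fluoro. Nothing measured here accounts for the difference between these two groups.

From the compounds shown here alone, whether a methoxy group, an amine or a carboxylic acid on this carbon would follow cyano or fluoro remains open. Also open, going by these compounds, is whether the cyano step would hold with the chloro on the other ring replaced.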